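A Chloro Substituent on the Benzothiazole of Compound 3

The source may report more compounds than this note shows. Statements on the series, on what has been measured and on what is new or still open speak of the compounds shown alone.

Compound 1 `Nc1nc(Cl)c(-c2ccccn2)c(N[C@@H]2C[C@H](CO)[C@@H](O)[C@H]2O)n1`: in an ADME assay on cells (Homo sapiens) for cytotoxicity, read by polymerase chain reaction, with a stated time of 3 days (on this read-out higher numbers stand for lower toxicity in this test and lower numbers for higher toxicity in this test), compound 1 gives > 25000 nM, a limit of the assay rather than a number.
Compound 2 `Nc1nc(Cl)c(-c2ccco2)c(N[C@@H]2C[C@H](CO)[C@@H](O)[C@H]2O)n1`: in this assay compound 2 gives > 25000 nM, again a limit of the assay.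
Compound 3 `Nc1nc(Cl)c(-c2nc3ccccc3s2)c(N[C@@H]2C[C@H](CO)[C@@H](O)[C@H]2O)n1`: in this assay compound 3 gives 14000 nM.

Among the compounds with values here, compound 3 thus carries the only number among the three, the other two values sitting at the limit of > 25000 nM in this assay, at which 2 of the 3 values shown sit. Compound 4 `Nc1nc(Cl)c(-c2nc3ccc(Cl)cc3s2)c(N[C@@H]2C[C@H](CO)[C@@H](O)[C@H]2O)n1` differs from compound 3 by chloro in place of hydrogen on an aromatic carbon. The measured steps that touch compound 3, an at least 1.7-fold lower number from compound 1 to compound 3 (0.25 log units; that floor lies within the scatter) and an at least 1.7-fold lower number from compound 2 to compound 3 (0.25 log units; that floor lies within the scatter), each exchange the whole aromatic group, and the step that the two limits leave unreadable from compound 1 to compound 2 is unreadable; none of them concerns a chloro added to the benzothiazole. The step from compound 3 to compound 4 is therefore expected to stay within the scatter, a 1.4-fold lower number from compound 3 to compound 4 (0.15 log units; within the scatter). Compound 4 is estimated at 10000 nM, between 4000 nM and 25000 nM.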

Compound 4, half-maximal cytotoxic concentration: 16000 nM
Beside the measured number, compound 4's estimate is 1.6-fold (0.20 log units) below it; the measured number falls inside the stated range.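

In this assay, chloro in place of hydrogen on this aromatic carbon of the benzothiazole gives a 1.1-fold higher number from compound 3 to compound 4 (0.06 log units; within the scatter), so this change at this position shifts the read-out by no more than the usual scatter. This is also the first readable step with a number at both ends rather than a floor, as the other values are limits of the assay: the limit of > 25000 nM in this assay, at which 2 of the 4 values shown sit.

From the compounds shown here alone, whether an amine, a methoxy group or a carboxylic acid on the same aromatic carbon would also stay within the scatter remains open. So does the effect of chloro on the other carbons of that ring.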